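The source may hold more compounds than are shown below. What is called first, only, known or untested is meant among the compounds shown, and "the series" means these compounds.

Measured compounds:
- compound 1, `COC(=O)CCCCc1cnc(C(=O)CCCCCCc2ccccc2)o1`: 1.8 nM
- compound 2, `O=CCCCCc1cnc(C(=O)CCCCCCc2ccccc2)o1`: 14.6 nM

In an assay for inhibition of Fatty-acid amide hydrolase 1 (Rattus norvegicus), using a Dixon plot (a higher number here means a weaker inhibitor, a lower number a stronger inhibitor), compound 2 stands highest of the two numbers; its nearest neighbour is compound 1, with the step of an 8.1-fold higher number from compound 1 to compound 2 (0.91 log units; beyond the scatter) separating them, a change of hydrogen in place of methoxy on a carbonyl carbon.

Compound 3, `COCOCCCCCc1cnc(C(=O)CCCCCCc2ccccc2)o1`, is yet to be measured. Its change from compound 2 is (methoxymethoxy)methyl in place of formyl on a saturated chain carbon, four bonds along the chain from an aromatic carbon. Among the compounds with values here, only one measured step bears on this position: the step of an 8.1-fold higher number from compound 1 to compound 2 (0.91 log units; beyond the scatter) shows that the group on this chain end matters and that the formyl compound is the weaker of the pair. Compound 3 replaces the formyl with a chain bearing two ether oxygens, which stands closer to compound 1 than to compound 2 in the number of heavy atoms and acceptors. A step back toward lower numbers is therefore expected for compound 3, of size a 2.9-fold lower number from compound 2 to compound 3 (0.47 log units; beyond the scatter), though with wide uncertainty. The estimate for compound 3 in this assay is 5 nM, within 1.5 nM to 20 nM.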

Compound 3, inhibition constant: 24.1 nM
Compound 3: the middle estimate sits 4.8-fold (0.68 log units) below what was measured; the whole stated range lies below it.
By their numbers in this assay, from the lowest: compound 1; then compounds 2 and 3 (each within the scatter of the next).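

In this assay, the step of a 1.7-fold higher number from compound 2 to compound 3 (0.22 log units; within the scatter) shows that exchanging formyl for (methoxymethoxy)methyl, with more heavy atoms and one more hydrogen-bond acceptor, does not separate the two compounds at this chain end. The step of a 13-fold higher number from compound 1 to compound 3 (1.13 log units; beyond the scatter) shows that the ether-bearing group does not recover the low number of compound 1, so a larger group with two ether oxygens is no substitute here for methoxycarbonyl. No measurement at hand accounts for this difference.

The compounds shown leave open whether the methyl ester itself is needed, or whether a carboxylic acid or a primary amide at the same chain end would keep the number of compound 1. They also leave open how a shorter or longer chain carrying methoxycarbonyl would compare.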